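The compounds below may be only part of what the source reports. "The series", "measured", "known", "first", "only" and "open" are said of these compounds alone.

Compound 3 `CCOC(=O)C1=C(N/C=N/c2ccc([N+](=O)[O-])cc2)Nc2[nH]nc(C)c2C1c1ccc(N(C)C)cc1` stands highest of the three numbers in a functional assay on HepG2 cells (Homo sapiens) for inhibition, read by MTT assay, with a stated time of 48 h (a higher number here means a weaker inhibitor, a lower number a stronger inhibitor), where compound 3 gives 50900 nM. Compound 1 `CCOC(=O)C1=C(N/C=N/c2cccnc2Cl)Nc2[nH]nc(C)c2C1c1ccc(N(C)C)cc1` gives 4890 nM and compound 2 `CCOC(=O)C1=C(N/C=N/c2ccccn2)Nc2[nH]nc(C)c2C1c1ccc(N(C)C)cc1` gives 26200 nM; the change from compound 3 to compound 4 `CCOC(=O)C1=C(NN=C(C#N)C#N)Nc2[nH]nc(C)c2C1c1ccc(N(C)C)cc1` is a group of 6 heavy atoms (3 carbon, 3 nitrogen; no ring) in place of a group of 11 heavy atoms (7 carbon, 2 nitrogen, 2 oxygen; one six-membered aromatic ring of carbon only), on an amine nitrogen. Among the measured compounds shown here, no measured step removes the aromatic ring outright, so only the steps of a 10-fold higher number from compound 1 to compound 3 (1.02 log units; beyond the scatter) and a 1.9-fold higher number from compound 2 to compound 3 (0.29 log units; within the scatter) on the same double-bonded nitrogen bear on it, and they show that variation at this position moves this assay modestly at most. Compound 4 is therefore expected to stay near compound 3, with the step of a 1.3-fold lower number from compound 3 to compound 4 (0.10 log units; within the scatter) within the scatter, giving an estimated 40000 nM with a range of 8000 nM to 200000 nM.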

Compound 4, half-maximal inhibitory concentration: 13700 nM
For compound 4 the middle estimate is 2.9-fold (0.47 log units) above the measured one, and the stated range covers the measured number.
By their numbers in this assay, from the lowest: compound 1; then compounds 4, 2 and 3 (each within the scatter of the next, the first and the last beyond it).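

Compound 4 shows that in this assay this position does not need an aromatic ring: the ring-free group gives a 3.7-fold lower number from compound 3 to compound 4 (0.57 log units; beyond the scatter) and a 1.9-fold lower number from compound 2 to compound 4 (0.28 log units; within the scatter) on the same amine nitrogen. It does not match the 2-chloropyridin-3-yl group, however, giving a 2.8-fold higher number from compound 1 to compound 4 (0.45 log units; beyond the scatter) in the same assay. No measured evidence here accounts for these steps.

The compounds shown leave open how a small acyclic group such as a carboxylic acid or a simple amine would behave at this nitrogen. They also leave open whether a pyridin-3-yl group without the chlorine would keep the standing of compound 1.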